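The source may report more compounds than this note shows. Statements on the series, on what has been measured and on what is new or still open speak of the compounds shown alone.

Compound 1 `Nc1c(C2=NCCN2)cnn1-c1cc(Cl)cc(Cl)c1`: 257000 nM
Compound 2 `Nc1c(C2=NCCCN2)cnn1-c1cccc(Cl)c1`: > 500000 nM

Both compounds were tested in an ADME assay on Vero cells (Chlorocebus sabaeus) for cytotoxicity, read by CellTiter-Glo and ATP content, with a stated time of 72 h; a lower number here means that less compound is tolerated, a higher number that more compound is tolerated. Compound 2 stands at > 500000 nM, which is a limit of the assay and not a number. Its true value is therefore unknown, and it cannot be placed exactly against compound 1.

Compound 3 `Nc1c(C2=NCCCN2)cnn1-c1cc(Cl)cc(Cl)c1` is built from compound 2 by one small edit: chloro in place of hydrogen on an aromatic carbon, meta to a chloro group (chloro in place of hydrogen on an aromatic carbon). Within the data shown here, no measured pair of compounds shows this change alone, so any forecast rests on thin evidence. The aromatic ring of compound 3 carries the same chloro groups as that of compound 1, and compound 1 gives 257000 nM. That value is the closest guide available in this assay. A modest move towards a lower number is therefore expected, meaning that somewhat less compound would be tolerated. The expected step of an at least 2.0-fold lower number from compound 2 to compound 3 (0.30 log units; that floor lies within the scatter) remains uncertain in size. For compound 3 the estimated value is 250000 nM, with an expected range from 110000 nM to 500000 nM.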

Compound 3, half-maximal cytotoxic concentration: > 500000 nM
Compound 3: a limit, no number; the forecaster's own chance of this, stated with the estimate: 25%; middle value at least 2.0-fold (0.30 log units) from the limit.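

In this assay compound 3 gives > 500000 nM, which is a limit of the assay and not a number. Adding the second chloro group to the aromatic ring therefore brings no measurable value into view, and the step from compound 2 cannot be read, since both of its ends are limits: the limit of > 500000 nM in this assay, at which 2 of the 3 values shown sit.

Among these compounds, with the chloro groups held the same, the one readable step replaces the five-membered non-aromatic ring with the six-membered one and gives an at least 1.9-fold higher number from compound 1 to compound 3 (0.28 log units; that floor lies within the scatter), so no drop in the tolerated amount appears with the larger ring, though a real gain remains unproven.

Going by these compounds, how far the true values of compound 2 and compound 3 lie past the limit stays open, and so does the size of any effect of the added chloro group at this position. Also open, on these data alone, is whether an amine or a carboxylic acid on that aromatic carbon, in place of the chloro group, would give a value that can be read as a number in this assay.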